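This account rests on a few compounds, and the source may have more. Where it says the series, first, only, none or still open, it means among the compounds named here.

Measured so far:
- compound 1, `O=S(=O)(NCCCNc1nccc(-c2c(-c3cccc(F)c3)nc3sccn23)n1)c1ccc(C(F)(F)F)cc1`: 4090 nM
- compound 2, `Cc1ccc(C(=O)NCCNc2nccc(-c3c(-c4cccc(F)c4)nc4sccn34)n2)cc1`: 5880 nM

In a functional assay on A-375 cells (Homo sapiens) for cytotoxicity, read by MTT assay (on this read-out higher numbers stand for weaker inhibition and lower numbers for stronger inhibition), compound 2 gives 5880 nM, the higher of the two numbers; compound 1 gives 4090 nM, and the gap between them lies within the scatter, so no order can be read. Within the data shown here, no step between measured pairs is available. Compound 3, `O=S(=O)(NCCCNc1nccc(-c2c(-c3cccc(F)c3)nc3sccn23)n1)c1ccc(F)cc1`, not yet measured, differs from compound 2 as follows: (((4-fluorophenyl)sulfonyl)amino)methyl in place of ((4-methylphenyl)carbonyl)amino on a saturated chain carbon, two bonds along the chain from a nitrogen on an aromatic ring. For this change a step no larger than the scatter is expected in either direction, a 1.3-fold lower number from compound 2 to compound 3 (0.12 log units; within the scatter). Compound 3 is therefore estimated at 4500 nM, with a range from 1800 nM to 11000 nM.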

Compound 3, half-maximal inhibitory concentration: 14500 nM
Compound 3: middle estimate off by 3.2-fold (0.51 log units), on the low side; the whole stated range lies below it.
By their numbers in this assay, from the lowest: compounds 1 and 2 (each within the scatter of the next); then compound 3.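

Fluoro in place of trifluoromethyl on an aromatic carbon gives a 3.5-fold higher number from compound 1 to compound 3 (0.55 log units; beyond the scatter) in this assay and is the first change confined to this position, showing that this substituent can move the number beyond the scatter. The exchange on the saturated chain carbon gives a 2.5-fold higher number from compound 2 to compound 3 (0.39 log units; beyond the scatter) but replaces the carbonyl with sulfonyl and alters the aromatic substituent and chain together. Nothing available accounts for either step.

As far as these compounds go, whether chloro or methoxy on that aromatic carbon would track with trifluoromethyl or fluoro remains open. Also open, from the compounds shown here alone, is how much of the step from the carbonyl compound belongs to the sulfonyl and how much to the added chain carbon.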